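A few compounds are considered here, and "the series" means these few. Any claim that something is new, unique, unknown or untested is made for them only; others in the source may bear on it.

Measured compounds in a physicochemical assay for solubility, at pH 2; on this read-out lower numbers stand for lower solubility and higher numbers for higher solubility:
- compound 1, `CC(C)Nc1nc(N(C)C)c2ccccc2n1`: >= 30000 nM
- compound 2, `CCCCNc1nc(NCCCC)c2ccccc2n1`: >= 30000 nM
- compound 3, `CNc1nc(NCc2ccccc2)nc2ccccc12`: >= 30000 nM

Each of these three values is a limit of this assay, not a number. For compound 1 the result >= 30000 nM is such a limit. For compound 2 the result >= 30000 nM is likewise a limit. Compound 3 also sits at this limit, with >= 30000 nM; the three compounds therefore cannot be ranked against one another, as the limit of >= 30000 nM in this assay, at which 3 of the 3 values shown sit, shows. Going by the values given here, no two measured compounds differ in a single place, so no measured step is available on which a size could be read.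

Compound 4, `CCCCNc1nc(NCc2ccccc2)nc2ccccc12`, is not yet measured in this assay. It differs from compound 3 by propyl in place of hydrogen on a saturated chain carbon bound to a nitrogen on an aromatic ring. Since every measured value in the series is a limit, including compound 3 with >= 30000 nM, the change can only be weighed against the position of that limit. The expectation is that compound 4 also reaches the limit, so the step from compound 3 to compound 4 is expected to be a number no higher from compound 3 to compound 4 (the limit leaves the size open), that is, none beyond the scatter as far as the assay can show. Compound 4 is estimated at 30000 nM, within 8000 nM to 100000 nM, with a fair chance that only a limit is reported again.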

Compound 4, solubility: >= 30000 nM
Compound 4 gave a limit, no number; the forecaster's own chance of this, stated with the estimate: 70%; the middle value lies on the limit itself.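

In this assay compound 4 gives >= 30000 nM, which is a limit and not a number. No new step can be read from compound 3 or compound 2 to compound 4, as all three values are limits: the limit of >= 30000 nM in this assay, at which 4 of the 4 values shown sit.

The compounds shown leave open how far any of them lies beyond this limit, and whether the changes among them alter the read-out at all.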